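Lengthening a Saturated Chain: Expectations for Lipophilicity

A few compounds are considered here, and "the series" means these few. Any claim that something is new, unique, unknown or untested is made for them only; others in the source may bear on it.

Three measured compounds share one core and differ only in the length of a saturated chain attached to an amine nitrogen. Compound 1 `CCCN(C)/N=N/c1ccc(C(=O)O)cc1` gives 0.46 in a physicochemical assay for lipophilicity; on this read-out lower numbers stand for lower lipophilicity and higher numbers for higher lipophilicity. Compound 2 `CCCCN(C)/N=N/c1ccc(C(=O)O)cc1` gives 0.97 in this assay, and compound 3 `CCCCCCCN(C)/N=N/c1ccc(C(=O)O)cc1` gives 2.58 in this assay. The change from compound 1 to compound 2 is methyl in place of hydrogen on a saturated chain carbon, three bonds along the chain from an amine nitrogen and brings a number 0.51 log units higher from compound 1 to compound 2 (beyond the scatter). The change from compound 1 to compound 3 is butyl in place of hydrogen on a saturated chain carbon, three bonds along the chain from an amine nitrogen and brings a number 2.12 log units higher from compound 1 to compound 3 (beyond the scatter), while the further step between the measured compounds reads a number 1.61 log units higher from compound 2 to compound 3 (beyond the scatter). Within these three compounds each added chain carbon has raised the value, and compound 3 stands highest, with both steps to it beyond the scatter.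

Compound 4 `CCCCCCCCN(C)/N=N/c1ccc(C(=O)O)cc1` has not yet been measured. It differs from compound 3 by methyl in place of hydrogen on a saturated chain carbon, seven bonds along the chain from an amine nitrogen. This is the same kind of change that turns compound 1 into compound 2, though the place is not identical: in the measured pair the new methyl sits three bonds along the chain from the amine nitrogen, whereas here it sits seven bonds along. The two cores themselves differ by butyl in place of hydrogen on a saturated chain carbon, three bonds along the chain from an amine nitrogen.

The step from compound 3 to compound 4 is expected to be a number 0.52 log units higher from compound 3 to compound 4 (beyond the scatter) in this assay, which rests on the earlier step of the same kind, a number 0.51 log units higher from compound 1 to compound 2 (beyond the scatter), and on the fact that the larger steps of a number 1.61 log units higher from compound 2 to compound 3 (beyond the scatter) and a number 2.12 log units higher from compound 1 to compound 3 (beyond the scatter) correspond to a comparable increase for each added carbon. Compound 4 is therefore estimated at 3.1, most likely between 2.7 and 3.5.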

Compound 4, partition coefficient: 2.77
The estimate for compound 4 lay 0.33 log units above the measured number; low and high end bracket the measured number.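

In this assay methyl in place of hydrogen, three bonds along the chain from an amine nitrogen, gives a number 0.51 log units higher from compound 1 to compound 2 (beyond the scatter) but, seven bonds along the chain, gives a number 0.19 log units higher from compound 3 to compound 4 (within the scatter) and so, in this one pair, the change did not carry to the other core at a size that can be told from the scatter. The wider steps, a number 1.80 log units higher from compound 2 to compound 4 (beyond the scatter) and a number 2.31 log units higher from compound 1 to compound 4 (beyond the scatter) remain beyond the scatter, yet they do not show how much of the chain's contribution continues at its far end, and with the core and the place both differing, this comparison cannot separate one from the other. No supporting information bears on this result, and the two pairs alone give no explanation for it.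

As far as these compounds go, it remains open whether a nonyl or decyl chain on the shared core would stand clearly apart from compound 4 in this assay or stay within the scatter of it. From the compounds shown here alone, it is also open whether the same chain steps would hold with a methyl ester in place of the carboxylic acid.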